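Ester variation across the series

The source may report more compounds than this note shows. Statements on the series, on what has been measured and on what is new or still open speak of the compounds shown alone.

Compound 1 `CCOC(=O)c1c(-c2ccc(OC)c(OC)c2)csc1N` gives 100% in an assay on isolated protein for inhibition of protein kinase C zeta type (Homo sapiens), with stated times of 1 h and 2.5 min, tested at 30 uM; on this read-out higher numbers stand for more inhibition at the one concentration tested (going by the name of the read-out) and lower numbers for less inhibition. Compound 2 `COCCOC(=O)c1c(-c2ccc(OC)c(OC)c2)csc1N` gives 57% and compound 3 `COCC(C)OC(=O)c1c(-c2ccc(OC)c(OC)c2)csc1N` gives 49%, the lowest of the three numbers; against compound 2 it lies within the scatter, whereas a number 51 percentage points lower from compound 1 to compound 3 (beyond the scatter) is large. Compound 4 `COc1ccc(-c2csc(N)c2C(=O)Oc2ccccc2)cc1OC` differs from compound 3 by phenyl in place of 1-(methoxymethyl)ethyl on an oxygen next to a carbonyl group. The steps bearing on this are a number 43 percentage points lower from compound 1 to compound 2 (beyond the scatter) and a number 51 percentage points lower from compound 1 to compound 3 (beyond the scatter), both showing that enlarging the ester from ethyl lowered inhibition, while a number 8 percentage points lower from compound 2 to compound 3 (within the scatter) shows one added methyl changing little. Among the compounds with values here, no measured step involves an aromatic ester, so the direction is uncertain, and only a modest step is expected: a number 6 percentage points higher from compound 3 to compound 4 (within the scatter) in this assay. Compound 4 is therefore estimated at 55%, between 20% and 90%.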

Compound 4, a percentage reported as inhibition, at one concentration (the size of the read-out at that concentration, not a potency): 48%
Compound 4: middle estimate off by 7 percentage points, on the high side; low and high end bracket the measured number.
By their numbers in this assay, from the lowest: compounds 4, 3 and 2 (each within the scatter of the next); then compound 1.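

Phenyl on an oxygen next to a carbonyl group brings the first ring to this position, and in this assay it cannot be told apart from 1-(methoxymethyl)ethyl (a number 1 percentage points lower from compound 3 to compound 4 (within the scatter)) or from 2-methoxyethyl (a number 9 percentage points lower from compound 2 to compound 4 (within the scatter)). Only ethyl stands apart (a number 52 percentage points lower from compound 1 to compound 4 (beyond the scatter)), so among these four compounds the loss does not depend on an ether oxygen in the ester group. No further data bear on this result.

The compounds shown leave open how a shorter group such as methyl compares with ethyl. Also open, as far as these compounds go, is whether benzyl on this oxygen, or an amide in place of the ester, reads with ethyl or with phenyl.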